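A second chloro group on compound 1

The compounds below may be only part of what the source reports. "The series", "measured", "known", "first", "only" and "open" are said of these compounds alone.

- Compound 1 (`CSc1nccc(N2CCC(N(C)Cc3ccccc3Cl)CC2)n1`) gives 1990 nM in a functional assay on BT-474 cells (Homo sapiens) for inhibition, read by luminescence, with a stated time of 72 h; on this read-out lower numbers stand for stronger inhibition and higher numbers for weaker inhibition
- Compound 2 (`CSc1nccc(N2CCC(N(C)Cc3c(F)cccc3Cl)CC2)n1`) gives 1040 nM in this assay

For the measured compounds named here, compound 1 has only one measured neighbour, compound 2, and their two values lie within the scatter of each other. Compound 3 (`CSc1nccc(N2CCC(N(C)Cc3ccc(Cl)cc3Cl)CC2)n1`) differs from compound 1 by chloro in place of hydrogen on an aromatic carbon, which turns 2-chlorophenyl into 2,4-dichlorophenyl. Going by the values given here, the only measured step, fluoro in place of hydrogen on an aromatic carbon, is a 1.9-fold lower number from compound 1 to compound 2 (0.28 log units; within the scatter), and it involves a different group. Among the compounds with values here, no measurement yet shows chloro entering at this place. A change beyond the scatter in this assay is therefore not expected. The expected step is a 1.5-fold lower number from compound 1 to compound 3 (0.18 log units; within the scatter), a modest one. Compound 3 is estimated at 1300 nM, within an expected range from 550 nM to 3000 nM, pending its measurement.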

Compound 3, half-maximal inhibitory concentration: 1620 nM
Beside the measured number, compound 3's estimate is 1.2-fold (0.10 log units) below it, and the stated range covers the measured number.
By their numbers in this assay, from the lowest: compounds 2, 3 and 1 (each within the scatter of the next).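

In this assay, chloro in place of hydrogen on the aromatic carbon para to a large group, which turns 2-chlorophenyl into 2,4-dichlorophenyl, gives a 1.2-fold lower number from compound 1 to compound 3 (0.09 log units; within the scatter) and so stays within the scatter. Replacing 2-chloro-6-fluorophenyl with 2,4-dichlorophenyl gives a 1.6-fold higher number from compound 2 to compound 3 (0.19 log units; within the scatter), so neither halogen pattern separates itself from the others here. No evidence on this result is available.

From the compounds shown here alone, whether an amine or a carboxylic acid at this place would move the number beyond the scatter remains open.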